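From Methyl to Isopropyl on a Shared Core

The source may hold more compounds than are shown below. What is called first, only, known or untested is meant among the compounds shown, and "the series" means these compounds.

Values in a physicochemical assay for solubility, in phosphate buffer, with a stated time of 18 h; a lower number here means a less soluble compound, a higher number a more soluble compound
- compound 1 `CC(C)(C)c1ccc2c(N)c(C#N)c(N)nc2n1` gives 14200 nM
- compound 2 `Cc1ncc2c(N)c(C#N)c(N)nc2n1` gives 783000 nM

Going by the values given here, of these two numbers, the one for compound 2 is the higher, and its gap to compound 1 lies well beyond the usual scatter. Compound 3 `CC(C)c1ncc2c(N)c(C#N)c(N)nc2n1` differs from compound 2 in one place, with isopropyl in place of methyl on an aromatic carbon. Among the compounds with values here, no two measured compounds show this change alone, so this assay offers no direct size for it. Compound 1 at 14200 nM differs from compound 2 in more than one place, which makes it only a loose guide. A moderate fall beyond the scatter, far smaller than the gap between those two compounds, is still expected. The estimated step of a 3.6-fold lower number from compound 2 to compound 3 (0.55 log units; beyond the scatter) is a judgement only. The expected value for compound 3 is 220000 nM in an estimated range of 60000 nM to 600000 nM at its two ends.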

Compound 3, solubility: > 1000000 nM
Compound 3: no number, only a limit; the forecaster's own chance of this, stated with the estimate: 5%; at least 4.5-fold (0.65 log units) between middle value and limit.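

Going by these compounds alone, at this position, between two ring nitrogen atoms, the change from methyl to isopropyl brings no visible loss in this assay, which the earlier compounds could not show. Compound 3 gives only a limit of the assay, > 1000000 nM, and not a number. The change can therefore be read only as an at least 1.2-fold higher number from compound 2 to compound 3 (0.10 log units; that floor lies within the scatter), so its true size is unknown, and the floor alone does not separate the two compounds: the limit of > 1000000 nM in this assay, at which 1 of the 3 values shown sits.

The compounds shown leave open how far compound 3 really lies from compound 2, and whether a longer chain, an amine or a carboxylic acid at this position would read the same way in this assay. They also leave open whether isopropyl in place of methyl would give a similar result on the core of compound 1.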